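Removing the hydroxy from compound 1

The source may report more compounds than this note shows. Statements on the series, on what has been measured and on what is new or still open speak of the compounds shown alone.

Measured in a functional assay on the whole organism (Hindlimb, strain albino) with Mus musculus as the target, in the maximal electroshock model, with a stated time of 0.5 h; a lower number here means that less compound is needed, a higher number that more compound is needed for the effect:
Compound 1 `COc1ccc(C2CC(Nc3nc4ccc(Cl)cc4s3)=NN2C(C)=O)cc1O` gives 127 umol/kg
Compound 2 `COc1ccc(C2CC(Nc3nc4ccc(C)cc4s3)=NN2C(C)=O)cc1O` gives 73.9 umol/kg
Compound 3 `COc1ccc(C2CC(Nc3nc4ccccc4s3)=NN2C(C)=O)cc1O` gives 259 umol/kg

Compound 1 sits among close neighbours. Its nearest is reached by a 1.7-fold lower number from compound 1 to compound 2 (0.24 log units; within the scatter), and its furthest by a 2.0-fold higher number from compound 1 to compound 3 (0.31 log units; beyond the scatter). The next compound, compound 4 `COc1ccc(C2CC(Nc3nc4ccc(Cl)cc4s3)=NN2C(C)=O)cc1`, keeps the chloro group of compound 1 and changes the aryl group instead, from 3-hydroxy-4-methoxyphenyl to 4-methoxyphenyl: hydrogen in place of hydroxy on an aromatic carbon.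

Among the measured compounds shown here, no measured step touches this hydroxy. All three swap chloro, methyl or hydrogen at a different place on the shared core, so they bear on the new change only indirectly. They show what size of step this series gives in this assay, and even a 3.5-fold higher number from compound 2 to compound 3 (0.54 log units; beyond the scatter) stays modest. The data give no direction for the loss of the hydroxy, so no step beyond the scatter is expected, though a modest one either way remains possible.

The expected result is a 1.1-fold lower number from compound 1 to compound 4 (0.02 log units; within the scatter). For compound 4 the estimated value is 120 umol/kg, expected to fall between 45 umol/kg and 300 umol/kg.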

Compound 4, dose for half-maximal effect: 93.3 umol/kg
Estimate against measurement, compound 4: 1.3-fold (0.11 log units) above, within the range that was stated.
By their numbers in this assay, from the lowest: compounds 2, 4 and 1 (each within the scatter of the next); then compound 3.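

In this assay, among the compounds shown here, this is the first direct reading of the hydroxy ortho to a methoxy group, and it gives a 1.4-fold lower number from compound 1 to compound 4 (0.13 log units; within the scatter). With the chloro group kept, the 3-hydroxy-4-methoxyphenyl group can therefore give way to 4-methoxyphenyl without a step beyond the scatter, even though a hydrogen-bond donor and a hydrogen-bond acceptor leave with the hydroxy. The compounds shown offer no measurement that would explain this outcome.

As far as these compounds go, this reading comes from the chloro compounds alone, so it remains open whether removing the hydroxy would give a similarly small step alongside the methyl or hydrogen of the shared core. From the compounds shown here alone, it also remains open how an amine, a fluoro group or a longer ethoxy chain would behave at this same place on the ring.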